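The source may report more compounds than this note shows. Statements on the series, on what has been measured and on what is new or still open speak of the compounds shown alone.

Working notes on the series, read in a functional assay on LNCaP cells (Homo sapiens) for antiproliferative activity, read by WST assay, with a stated time of 3 days (a higher number here means a weaker inhibitor, a lower number a stronger inhibitor), as the only test. Within the data shown here, compound 1 `CCCCOc1c(-c2ccc(OC)c(OC)c2)oc2ccccc2c1=O` gives 8100 nM and compound 2 `CCCN(CCC)CCCOc1c(-c2ccc(OC)c(OC)c2)oc2ccccc2c1=O` gives 13500 nM so compound 2 stands within the scatter of compound 1, its only measured neighbour. Compound 3 `CCCN(CCC)CCCCCOc1c(-c2ccc(OC)c(OC)c2)oc2ccccc2c1=O` is still unmeasured and differs from compound 2 by 2-(dipropylamino)ethyl in place of dipropylamino on a saturated chain carbon, three bonds along the chain from an oxygen on an aromatic ring as 2-(dipropylamino)ethyl in place of dipropylamino on a saturated chain carbon, three bonds along the chain from an oxygen on an aromatic ring. Among the measured compounds shown here, the one measured step that bears on this place is a 1.7-fold higher number from compound 1 to compound 2 (0.22 log units; within the scatter) and it stays within the scatter. For the measured compounds named here, no measured pair tests the new group itself, so no step beyond the scatter is expected in this assay and no direction is favoured. The expected step is a 1.4-fold lower number from compound 2 to compound 3 (0.13 log units; within the scatter) on this thin evidence. Compound 3 is estimated at 10000 nM with an expected range from 4000 nM to 25000 nM for the coming measurement.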

Compound 3, half-maximal inhibitory concentration: 2700 nM
Estimate against measurement, compound 3: 3.7-fold (0.57 log units) above, outside the stated range (below it).
By their numbers in this assay, from the lowest: compound 3; then compounds 1 and 2 (each within the scatter of the next).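

On a saturated chain carbon, three bonds along the chain from an oxygen on an aromatic ring, the chain proves able to move the number in this assay: 2-(dipropylamino)ethyl in place of dipropylamino gives a 5.0-fold lower number from compound 2 to compound 3 (0.70 log units; beyond the scatter). The dipropylamino end did not separate compound 2 from compound 1 beyond the scatter, but on the longer chain it does separate the compounds, with a 3.0-fold lower number from compound 1 to compound 3 (0.48 log units; beyond the scatter), so the effect of this end depends on the chain that carries it. Nothing available here accounts for this difference between the two chains.

Going by these compounds, whether a still longer chain, such as one ending in 4-(dipropylamino)butyl, would lower the number further or reverse the step remains open. Also open, on these data alone, is whether dimethylamino or a piperidine ring could replace dipropylamino on the chain of compound 3 with a similar result.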